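A Second Methyl for Compound 4: What Is Expected

The compounds below may be only part of what the source reports. "The series", "measured", "known", "first", "only" and "open" are said of these compounds alone.

Three compounds have been measured in a functional assay on A549 cells (Homo sapiens) for cytotoxicity, read by MTT assay, with a stated time of 72 h; on this read-out lower numbers stand for stronger inhibition and higher numbers for weaker inhibition:

Compound 1, `Cc1cccc(-c2ccnc(C(=O)Nc3ccc(Oc4ccnc5[nH]ccc45)cc3)c2)c1`, gives 7010 nM.
Compound 2, `O=C(Nc1ccc(Oc2ccnc3[nH]ccc23)cc1)c1cc(-c2ccccc2)ccn1`, gives 2920 nM.
Compound 3, `Cc1ccc(-c2ccnc(C(=O)Nc3ccc(Oc4ccnc5[nH]ccc45)c(F)c3)c2)cc1`, gives 3120 nM.

Compound 1 and compound 2 differ in one place, by methyl in place of hydrogen on an aromatic carbon. That change brought a 2.4-fold higher number from compound 2 to compound 1 (0.38 log units; beyond the scatter), a modest step that nonetheless lies beyond the scatter of this assay. Compound 3 carries a core that differs from that of compound 2 in more than one place; the difference between the two cores is not broken down here. Their two values lie within the scatter of each other, so nothing can be said about order between compound 2 and compound 3.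

Compound 4, `Cc1ccc(-c2ccnc(C(=O)Nc3ccc(Oc4ccnc5[nH]ccc45)c(F)c3)c2)c(C)c1`, is not yet measured. It differs from compound 3 by methyl in place of hydrogen on an aromatic carbon. This is the same kind of change as that from compound 2 to compound 1, but not the same: the earlier methyl entered meta to a large group, whereas the new one enters ortho to a large group and meta to a methyl group. With a single precedent at a different place, the expectation rests on one step only. An expected step of a 1.6-fold higher number from compound 3 to compound 4 (0.20 log units; within the scatter) is taken, a little smaller than the earlier one because a 2.4-fold higher number from compound 2 to compound 1 (0.38 log units; beyond the scatter) was itself modest and the place is not the same. Compound 4 is therefore estimated at 5000 nM in this assay, with an expected range from 2000 nM to 12500 nM.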

Compound 4, half-maximal inhibitory concentration: 4350 nM
The estimate for compound 4 lay 1.1-fold (0.06 log units) above the measured number, and the stated range covers the measured number.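

In this assay, turning the 4-methylphenyl of compound 3 into the 2,4-dimethylphenyl of compound 4 brought a 1.4-fold higher number from compound 3 to compound 4 (0.14 log units; within the scatter), so on this core the added methyl gives a step that cannot be told apart from repeated measurement. Set beside the earlier methyl step, the new one does not differ from it, and the data therefore give no sign that the size of this change depends on the core: the same change on two cores in this assay, a 2.4-fold higher number (0.38 log units; beyond the scatter) from compound 2 to compound 1 and a 1.4-fold higher number (0.14 log units; within the scatter) from compound 3 to compound 4, 1.7-fold (0.24 log units) apart, within the scatter of two such steps. Going by these compounds alone, this does not show that the change carries over from one core to another with a fixed size, since only two pairs are available, they differ in the place of the methyl as well as in the core, and one of the two steps lies beyond the scatter while the other lies within it.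

The compounds shown leave open how an ethyl group, a methoxy group or an amine would read in this assay at the place taken by the new methyl, ortho to a large group. They also leave open how a methyl at that same place would read on the core of compound 2, which would separate the place of the methyl from the difference between the cores.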